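The source may report more compounds than this note shows. Statements on the series, on what has been measured and on what is new or still open speak of the compounds shown alone.

Compound 1 `COc1cccc(NC(=O)N[C@@H]2C3CCN(CC3)[C@@H]2Cc2cccnc2)c1`, compound 2 `O=C(Nc1cccc(F)c1)N[C@@H]1C2CCN(CC2)[C@@H]1Cc1cccnc1` and compound 3 `O=C(Nc1ccc(Cl)c(Cl)c1)N[C@@H]1C2CCN(CC2)[C@@H]1Cc1cccnc1` share one core and differ only in the aromatic group on the amide-type nitrogen. In an assay on a protein complex for binding affinity to Neuronal acetylcholine receptor; alpha4/beta2 (Homo sapiens) (on this read-out higher numbers stand for weaker inhibition and lower numbers for stronger inhibition), compound 1 gives only a limit of the assay, > 10000 nM. Compound 2 likewise gives a limit in this assay, > 10000 nM. Compound 3 also gives a limit in this assay, > 10000 nM. Because all three sit at the limit of > 10000 nM in this assay, at which 3 of the 3 values shown sit, the steps a step that the two limits leave unreadable from compound 1 to compound 2, a step that the two limits leave unreadable from compound 1 to compound 3 and a step that the two limits leave unreadable from compound 2 to compound 3 cannot be read in size or direction. Compound 3 therefore stands at a limit of the assay, with no number of its own. Compound 4 `CN(C)c1ccc(NC(=O)N[C@@H]2C3CCN(CC3)[C@@H]2Cc2cccnc2)cc1` arises from compound 3 by the change (4-(dimethylamino)phenyl in place of 3,4-dichlorophenyl on an amide-type nitrogen). No measured step gives a readable size for this change; the three comparisons show only that each aromatic group tried among these compounds left binding at the limit. The step from compound 3 to compound 4 is therefore expected to stay within the unreadable region, a step that the limit leaves unreadable from compound 3 to compound 4. Compound 4 is estimated to give 15000 nM in this assay, within a range from 3000 nM to 60000 nM.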

Compound 4, inhibition constant: > 10000 nM
Compound 4 ended at the assay's limit; the forecaster's own chance of this, stated with the estimate: 80%; the middle value is on the limit's open side.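

Compound 4 also gives only a limit of the assay, > 10000 nM, so its steps from compound 1, compound 2 and compound 3 cannot be read in size or direction: the limit of > 10000 nM in this assay, at which 4 of the 4 values shown sit.

The compounds shown leave open how strongly any of these four binds in this assay, and which aromatic group on the amide-type nitrogen, if any, would give a readable number.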